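The compounds below may be only part of what the source reports. "The series", "measured", "known", "first", "only" and "open" are said of these compounds alone.

Measured so far:
- Compound 1, `O=C(/C=C/c1ccc(OC(F)(F)F)cc1)Nc1nnc(-c2ccccc2)[nH]1`: 1560000 nM
- Compound 2, `COc1ccc(/C=C/C(=O)Nc2nnc(-c3ccccc3)[nH]2)cc1`: 1280000 nM

Compound 2 stands beside compound 1 on the numbers shown: in an ADME assay on Vero cells (Chlorocebus sabaeus) for cytotoxicity, read by MTT assay, with a stated time of 72 h (on this read-out higher numbers stand for lower toxicity in this test and lower numbers for higher toxicity in this test), compound 2 gives 1280000 nM, and the only step between them, a 1.2-fold lower number from compound 1 to compound 2 (0.09 log units; within the scatter), stays within the scatter, so the two values cannot be told apart.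

Compound 3, `O=C(/C=C/c1ccccc1)Nc1nnc(-c2ccccc2)[nH]1`, has not yet been measured in this assay. It differs from compound 2 in one place: hydrogen in place of methoxy on an aromatic carbon. Going by the values given here, no measured step touches the methoxy itself; the single step in hand, a 1.2-fold lower number from compound 1 to compound 2 (0.09 log units; within the scatter), changed the group on the same oxygen and moved the number only within the scatter. Nothing measured therefore points to a shift in either direction, and a step of no more than the scatter is expected for compound 3 in this assay.

The estimate for compound 3 in this assay is 1300000 nM, with a range of 600000 nM to 2800000 nM, which means an expected step of a 1.0-fold higher number from compound 2 to compound 3 (0.01 log units; within the scatter).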

Compound 3, half-maximal cytotoxic concentration: 1570000 nM
Estimate against measurement, compound 3: 1.2-fold (0.08 log units) below, and the stated range covers the measured number.
By their numbers in this assay, from the lowest: compounds 2, 1 and 3 (each within the scatter of the next).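

In this assay, going by these compounds alone, the earlier compounds compared only two groups on the same oxygen, whereas compound 3 has no group at this place at all, with hydrogen on the aromatic carbon para to a large group. Taking away the whole methoxy gives a 1.2-fold higher number from compound 2 to compound 3 (0.09 log units; within the scatter), and taking away the whole trifluoromethoxy gives a 1.0-fold higher number from compound 1 to compound 3 (0.00 log units; within the scatter), so neither step can be told from repeat measurement and, across these three compounds, 4-methoxyphenyl and phenyl read alike, as does the trifluoromethoxy-bearing ring of compound 1. No available evidence bears on why these three values stay so close.

The compounds shown leave open whether any group at this place would give a step beyond the scatter, for instance an amine, a carboxylic acid or a longer chain on the oxygen. They also leave open whether this flat reading holds when the core itself is changed, such as the phenyl on the far ring or the amide hydrogen, since all three compounds share that core unchanged.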